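From trimethoxyphenyl to dibromohydroxyphenyl: a single step to go on

A few compounds are considered here, and "the series" means these few. Any claim that something is new, unique, unknown or untested is made for them only; others in the source may bear on it.

Values so far in a functional assay on A549 cells (Homo sapiens) for cytotoxicity, read by MTT assay, with a stated time of 72 h; a lower number here means a stronger inhibitor, a higher number a weaker inhibitor

- Compound 1 `COc1cc2ncnc(Nc3ccc(F)c(Cl)c3)c2cc1NC(=O)N/N=C/c1ccc([N+](=O)[O-])cc1` gives 35100 nM
- Compound 2 `COc1cc2ncnc(Nc3ccc(F)c(Cl)c3)c2cc1NC(=O)N/N=C/c1cc(OC)c(OC)c(OC)c1` gives 32100 nM

Compound 2 and compound 1 sit within the scatter of each other, so neither ranks ahead. Compound 3 `COc1cc2ncnc(Nc3ccc(F)c(Cl)c3)c2cc1NC(=O)N/N=C/c1cc(Br)c(O)c(Br)c1` keeps the shared core and changes one group (3,5-dibromo-4-hydroxyphenyl in place of 3,4,5-trimethoxyphenyl on a carbon with a double bond to nitrogen): 3,5-dibromo-4-hydroxyphenyl in place of 3,4,5-trimethoxyphenyl on a carbon with a double bond to nitrogen. Among the compounds with values here, only one measured step bears on this place (a 1.1-fold lower number from compound 1 to compound 2 (0.04 log units; within the scatter)), and it stayed within the scatter even though 4-nitrophenyl and 3,4,5-trimethoxyphenyl are quite different groups. Within the data shown here, no measured compound carries the entering group, so this is thin evidence. In this assay no step beyond the scatter is therefore expected, though the range stays wide. The estimated change (a 1.3-fold lower number from compound 2 to compound 3 (0.11 log units; within the scatter)) is expected to be small. Compound 3 is expected at 25000 nM (estimated range 8000 nM to 60000 nM).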

Compound 3, half-maximal inhibitory concentration: 34600 nM
Compound 3: the middle estimate sits 1.4-fold (0.14 log units) below what was measured, and the stated range covers the measured number.
By their numbers in this assay, from the lowest: compounds 2, 3 and 1 (each within the scatter of the next).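

In this assay, compound 3 cannot be separated from either earlier compound (a 1.1-fold higher number from compound 2 to compound 3 (0.03 log units; within the scatter); a 1.0-fold lower number from compound 1 to compound 3 (0.01 log units; within the scatter)). The entering 3,5-dibromo-4-hydroxyphenyl group brings two bromine atoms and a hydrogen-bond donor that 3,4,5-trimethoxyphenyl lacks, yet this place now holds three differently substituted phenyl groups with values all within the scatter of one another. Nothing else measured on these compounds helps to interpret this flat result.

All three groups shown are phenyl rings, so it remains open whether an amine, a carboxylic acid or a longer alkyl chain on this carbon would give a different value. The shared core is also the same throughout, which leaves open how the values respond to a change anywhere else in the molecule.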